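Two inactive amines and a third to be tested

The source may report more compounds than this note shows. Statements on the series, on what has been measured and on what is new or still open speak of the compounds shown alone.

Compound 1 `Cc1cc(NCCO)nc(SCc2nc3ccccc3[nH]2)n1`: > 100000 nM
Compound 2 `Cc1cc(Nc2cccc(C(F)(F)F)c2)nc(SCc2nc3ccccc3[nH]2)n1`: > 100000 nM

Compound 1 `Cc1cc(NCCO)nc(SCc2nc3ccccc3[nH]2)n1` was tested in a functional assay on ECa-109 cells (Homo sapiens) for cytotoxicity, read by MTT assay, with a stated time of 72 h (on this read-out lower numbers stand for stronger inhibition and higher numbers for weaker inhibition), where compound 1 reached only a limit of the assay, > 100000 nM, and no number. Compound 2 `Cc1cc(Nc2cccc(C(F)(F)F)c2)nc(SCc2nc3ccccc3[nH]2)n1`, which bears an aryl group on the same nitrogen, likewise reached only a limit in this assay, > 100000 nM. Both values therefore sit at the same limit (the limit of > 100000 nM in this assay, at which 2 of the 2 values shown sit), so compound 1 cannot be placed above or below compound 2.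

Compound 3 `Cc1cc(Nc2ccc(F)cc2)nc(SCc2nc3ccccc3[nH]2)n1` differs from compound 1 in one place: 4-fluorophenyl in place of 2-hydroxyethyl on a nitrogen on an aromatic ring. Among the measured compounds shown here, with no measured step between compounds to lean on, the account expects no step beyond the scatter in this assay, and the step from compound 1 to compound 3 is estimated as a step that the limit leaves unreadable from compound 1 to compound 3. For compound 3 the estimate in this assay is 150000 nM, between 40000 nM and 500000 nM, and a limit rather than a number is the likelier outcome.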

Compound 3, half-maximal inhibitory concentration: 69500 nM
The estimate for compound 3 lay 2.2-fold (0.33 log units) above the measured number, within the range that was stated.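

Among the compounds shown here, with 4-fluorophenyl in place of 2-hydroxyethyl on a nitrogen on an aromatic ring, compound 3 gives the first actual number in this assay, 69500 nM, and the change reads as an at least 1.4-fold lower number from compound 1 to compound 3 (0.15 log units; that floor lies within the scatter). The value for compound 1 is only a limit, so this step is a floor, and it shows only that this position can carry a group that gives a readable value on the shared core. Compound 3 is the only compound shown that leaves the limit: the limit of > 100000 nM in this assay, at which 2 of the 3 values shown sit.

From the compounds shown here alone, how far compound 1 truly lies from compound 3 stays open. Also open, going by these compounds, is how this nitrogen would read with an unsubstituted phenyl ring, a longer chain ending in an amine, or a phenyl ring bearing a carboxylic acid.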